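The source may report more compounds than this note shows. Statements on the series, on what has been measured and on what is new or still open speak of the compounds shown alone.

Measured compounds:
- compound 1, `CC(C)(C)Cc1csc(N)c1C(=O)c1cccc(Cl)c1`: 2%
- compound 2, `CC(C)(C)Cc1csc(N)c1C(=O)c1ccc(Cl)c(Cl)c1`: 1%

In an assay on CHO cells for displacement of a labelled ligand from adenosine receptor A1 (Homo sapiens), read by scintillation counting, tested at 10 uM (a higher number here means more inhibition at the concentration tested (going by the name of the read-out), a lower number less inhibition), compound 1 gives 2% and compound 2 gives 1%. Going by the values given here, both numbers sit close to zero, and the only measured step, a number 1 percentage points lower from compound 1 to compound 2 (within the scatter), is within the scatter, so compound 1 stands with compound 2 at the floor of this assay rather than apart from it.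

Compound 3, `CC(C)(C)Cc1csc(N)c1C(=O)c1cccc(C(F)(F)F)c1`, has not been measured. It differs from compound 1 in one place: trifluoromethyl in place of chloro on an aromatic carbon. Among the compounds with values here, the one measured step concerns the same aromatic ring of the shared core but a different exchange, chloro in place of hydrogen, and it produced nothing beyond the scatter. Within the data shown here, no step from chloro to trifluoromethyl has been measured, so the new exchange is not directly covered. Among the measured compounds shown here, with both measured compounds near zero and the single step flat, the expected change in this assay for compound 3 is a number 1 percentage points higher from compound 1 to compound 3 (within the scatter), that is, no step beyond the scatter. Compound 3 is therefore estimated at 3%, with an expected range from -8% to 14%.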

Compound 3, a percentage reported as inhibition, at one concentration (the size of the read-out at that concentration, not a potency): 1%
Compound 3: middle estimate off by 2 percentage points, on the high side; low and high end bracket the measured number.
By their numbers in this assay, from the lowest: compounds 2, 3 and 1 (each within the scatter of the next).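

In this assay, trifluoromethyl in place of chloro on this aromatic carbon, meta to a large group, gives a number 1 percentage points lower from compound 1 to compound 3 (within the scatter). Going by these compounds alone, the earlier step added a chloro, whereas this one exchanges the chloro at this place for a larger group, with 4 heavy atoms entering and 1 heavy atom leaving, and the number still stays at the floor of the assay, so a first exchange at this carbon has now been read and the larger group does not lift compound 3 away from compound 1. No measurement available here speaks to the reason for this flat result.

Whether an amine or a carboxylic acid on this aromatic carbon would move the number off the floor remains open, as the groups shown here at this place are only chloro and trifluoromethyl. Equally open, as far as these compounds go, is whether the picture stays flat when the changes fall elsewhere on the shared core, for example with an amide in place of the free amine or a shorter chain in place of the branched one.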